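A few compounds are considered here, and "the series" means these few. Any claim that something is new, unique, unknown or untested is made for them only; others in the source may bear on it.

Of the compounds shown here, three sharing one core have been measured in a physicochemical assay for lipophilicity, read by HPLC, measured as octanol-water partition; on this read-out lower numbers stand for lower lipophilicity and higher numbers for higher lipophilicity. Compound 1 `O=C1O[C@@H](CN2CCCCC2)CN1c1ccc(-n2cc(-c3ccccn3)cn2)c(F)c1` gives 3.1. Compound 2 `O=C1O[C@@H](CN2CCC(O)CC2)CN1c1ccc(-n2cc(-c3ccccn3)cn2)c(F)c1` gives 1.63, and compound 3 `CN(C)S(=O)(=O)NC[C@H]1CN(c2ccc(-n3cc(-c4ccccn4)cn3)c(F)c2)C(=O)O1` gives 1.38. Compound 3 has the lowest of the three numbers: its nearest neighbour is compound 2, with a gap a number 0.25 log units lower from compound 2 to compound 3 (within the scatter), and its furthest is compound 1, with a gap a number 1.72 log units lower from compound 1 to compound 3 (beyond the scatter). The step of a number 1.47 log units lower from compound 1 to compound 2 (beyond the scatter) shows how much a single hydroxy group shifted the number on its own.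

Compound 4 `COC(=O)NC[C@H]1CN(c2ccc(-n3cc(-c4ccccn4)cn3)c(F)c2)C(=O)O1` differs from compound 3 in one place: methoxycarbonyl in place of dimethylsulfamoyl on an amine nitrogen. Among the measured compounds shown here, no measured step exchanges one of these two groups for the other, so the expectation rests on indirect grounds. The two large steps, a number 1.72 log units lower from compound 1 to compound 3 (beyond the scatter) and a number 0.25 log units lower from compound 2 to compound 3 (within the scatter), each brought in the dimethylsulfamoyl group together with a change of the amine itself, and the gap between compound 2 and compound 3 was within the scatter. Swapping one small, uncharged group carrying two hydrogen-bond acceptors for another of the same description is expected to move this assay only a little, if at all, so a step of a number 0.22 log units higher from compound 3 to compound 4 (within the scatter) is estimated. Compound 4 is therefore expected to give about 1.6, most likely between 1.1 and 2.1.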

Compound 4, partition coefficient: 2.03
Compound 4: the middle estimate sits 0.43 log units below what was measured; the measured number falls inside the stated range.
By their numbers in this assay, from the lowest: compounds 3 and 2 (each within the scatter of the next); then compound 4; then compound 1.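

At this position, on an amine nitrogen whose other neighbour is a saturated chain carbon, the exchange of groups does register in this assay: methoxycarbonyl in place of dimethylsulfamoyl gives a number 0.65 log units higher from compound 3 to compound 4 (beyond the scatter) even though both groups have 2 hydrogen-bond acceptors, 0 donors and no net charge, so those counts alone do not settle the number here. The side chain now separates the compounds more finely than before: compound 2 and compound 3 lie within the scatter of each other, while (methoxycarbonyl)amino in place of 4-hydroxypiperidin-1-yl gives a number 0.40 log units higher from compound 2 to compound 4 (beyond the scatter) and the same group in place of piperidin-1-yl gives a number 1.07 log units lower from compound 1 to compound 4 (beyond the scatter) as the series now stands. Nothing available here accounts for the size of these steps.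

The two groups differ in several ways at once, including 4 against 6 heavy atoms and the sulfur, so a single exchange cannot show which difference carries the step. As far as these compounds go, a methylsulfonyl or an acetyl group on the same amine nitrogen would help to separate these differences, and whether the step holds on any other core remains open.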